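Swapping the sulfone tail for a hydroxybutyl chain on the bromo analogue

The compounds below may be only part of what the source reports. "The series", "measured", "known", "first", "only" and "open" are said of these compounds alone.

Within the data shown here, compound 3, `CS(=O)(=O)CCCn1c(Cn2c(=O)n(C3CC3)c3ccncc32)cc2cc(Br)ccc21`, is one of three compounds measured in an ADME assay on HeLa cells (Homo sapiens) for cytotoxicity, read by ATP content, with a stated time of 3 days; on this read-out higher numbers stand for lower toxicity in this test and lower numbers for higher toxicity in this test. In this assay compound 3 gives > 50000 nM, which is a limit of the assay rather than a number. Compound 1, `CS(=O)(=O)CCCn1c(Cn2c(=O)n(C3CC3)c3ccncc32)cc2ccccc21`, is the parent without the bromo substituent, and in this assay compound 1 gives > 100000 nM, likewise a limit. Compound 2, `O=c1n(Cc2cc3cc(Cl)ccc3n2CCCCO)c2cnccc2n1C1CC1`, carries chloro and a 4-hydroxybutyl chain, and in this assay compound 2 gives > 50000 nM, also a limit. Among the measured compounds shown here, the only pair that differs in one place is compound 1 and compound 3, where a step that the two limits leave unreadable from compound 1 to compound 3; the two limits of the limit of > 100000 nM in this assay, at which 1 of the 3 values shown sits, and the limit of > 50000 nM in this assay, at which 2 of the 3 values shown sit, leave the size of that step unreadable. Nothing measured here reaches a numbered cytotoxicity value.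

The next compound, compound 4, `O=c1n(Cc2cc3cc(Br)ccc3n2CCCCO)c2cnccc2n1C1CC1`, differs from compound 3 by hydroxymethyl in place of methylsulfonyl on a saturated chain carbon, three bonds along the chain from an aromatic nitrogen. For the measured compounds named here, no measured step concerns this change, and compound 2, which shares the 4-hydroxybutyl chain, shows only a limit. The step from compound 3 to compound 4 is therefore expected to be a step that the limit leaves unreadable from compound 3 to compound 4, nothing beyond the scatter and most likely another limit. Compound 4 is expected to give 70000 nM, in the range 30000 nM to 200000 nM.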

Compound 4, half-maximal cytotoxic concentration: > 50000 nM
Compound 4 was reported as a limit; the forecaster's own chance of this, stated with the estimate: 80%; the middle value does not contradict the limit.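

In this assay compound 4 also sits at a limit, so neither the change from compound 3 to compound 4 nor the change from compound 2 to compound 4 gives a step that can be read: the limit of > 50000 nM in this assay, at which 3 of the 4 values shown sit. The compounds shown leave open what the half-maximal cytotoxic concentration of any of them is, and whether either change shifts it at all.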